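This account rests on a few compounds, and the source may have more. Where it says the series, first, only, none or still open, it means among the compounds named here.

Measured compounds:
compound 1, `COc1ccc(C(=O)/C=C/c2cc(-c3cc(OC)c(OC)c(OC)c3)n[nH]2)cc1OC`: 2600 nM in a functional assay on TK-10 cells (Homo sapiens) for inhibition, read by sulforhodamine B assay, with a stated time of 48 h; on this read-out lower numbers stand for stronger inhibition of growth and higher numbers for weaker inhibition of growth
compound 2, `COc1cc(-c2cc(/C=C/C(=O)c3ccc(F)c(F)c3)[nH]n2)cc(OC)c1OC`: 7420 nM in this assay

Compound 1 stands at the lowest of the two numbers seen so far in this assay; its nearest neighbour is compound 2, and the gap between the two is beyond the scatter. Going by the values given here, the only step measured, a 2.9-fold higher number from compound 1 to compound 2 (0.46 log units; beyond the scatter), swaps one whole aromatic group on the carbonyl carbon for another and says nothing directly about adding a single substituent to the ring that is kept.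

Compound 3, `COc1cc(C(=O)/C=C/c2cc(-c3cc(OC)c(OC)c(OC)c3)n[nH]2)cc(OC)c1OC`, is built from compound 1 by the change (methoxy in place of hydrogen on an aromatic carbon). The entering methoxy sits ortho to a methoxy group and meta to a methoxy group and to a large group, so the ring already carrying two methoxy groups gains a third. Among the compounds with values here, no measured step shows what such an addition does; the one step available concerns a different exchange. The expectation for compound 3 is therefore a step of a 1.2-fold lower number from compound 1 to compound 3 (0.07 log units; within the scatter), that is, no change beyond the scatter, with a wide range. Compound 3 is estimated at 2200 nM, between 700 nM and 7000 nM.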

Compound 3, concentration for total growth inhibition: 2800 nM
Compound 3: the middle estimate sits 1.3-fold (0.10 log units) below what was measured; low and high end bracket the measured number.
By their numbers in this assay, from the lowest: compounds 1 and 3 (each within the scatter of the next); then compound 2.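

Placing a methoxy group on this aromatic carbon, ortho to a methoxy group and meta to a methoxy group and to a large group, gives a 1.1-fold higher number from compound 1 to compound 3 (0.03 log units; within the scatter) in this assay and so leaves growth inhibition unchanged within the usual scatter. The earlier step exchanged one whole aromatic group for another, whereas this one shows that a single added methoxy group at this position can be accommodated with no measurable gain or loss on this read-out. No supporting measurement is available to explain this flat result.

The compounds shown do not reveal whether this position would respond differently to a group other than methoxy, such as an amine, a carboxylic acid or a longer chain like butoxy. They also leave open whether a flat result would hold if the same methoxy group were added to a ring carrying other substituents, such as the 3,4-difluorophenyl group of compound 2, so this finding applies only to the pair compared here.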